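Ring swap at the amine position of compound 2

The source may hold more compounds than are shown below. What is called first, only, known or untested is meant among the compounds shown, and "the series" means these compounds.

In a functional assay on HEK293 cells for antagonist activity at transient receptor potential cation channel subfamily V member 1 (Rattus norvegicus), read by calcium flux (a higher number here means a weaker inhibitor, a lower number a stronger inhibitor), compound 1 `FC(F)(F)c1ccc(Nc2nc(N3CCC3)nc3sc(Nc4c(Cl)cccc4Cl)nc23)cc1` gives 25 nM and compound 2 `FC(F)(F)c1ccc(Nc2nc(N3CCCC3)nc3sc(Nc4c(Cl)cccc4Cl)nc23)cc1` gives 36 nM, the higher of the two numbers, with the step of a 1.4-fold higher number from compound 1 to compound 2 (0.16 log units; within the scatter) staying within the scatter. Compound 3 `FC(F)(F)c1ccc(Nc2nc(N3CCNCC3)nc3sc(Nc4c(Cl)cccc4Cl)nc23)cc1` carries the change piperazin-1-yl in place of pyrrolidin-1-yl on an aromatic carbon at the same position where that earlier swap happened. Among the measured compounds shown here, since the only measured step there barely moved the number, a modest rise of a 1.9-fold higher number from compound 2 to compound 3 (0.29 log units; within the scatter) is expected rather than a large one. Compound 3 is therefore estimated at 70 nM in this assay, within a range of 20 nM to 250 nM.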

Compound 3, half-maximal inhibitory concentration: > 5000 nM
Compound 3: no number, only a limit; the forecaster's own chance of this, stated with the estimate: 5%; middle value at least 71-fold (1.85 log units) away from the limit.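

The position between two ring nitrogen atoms tolerates azetidin-1-yl and pyrrolidin-1-yl alike, but not every ring: piperazin-1-yl gives an at least 130-fold higher number from compound 2 to compound 3 (2.14 log units; beyond the scatter) and an at least 200-fold higher number from compound 1 to compound 3 (2.30 log units; beyond the scatter). So the closeness of the first two compounds in this assay does not extend to all cyclic amines here. Compound 3 has no number, only a limit: the limit of > 5000 nM in this assay, at which 1 of the 3 values shown sits.

The change brings in a six-membered ring, a second ring nitrogen and a hydrogen-bond donor together, and compound 3 cannot separate them. Going by these compounds, whether piperidin-1-yl, morpholin-4-yl or 4-methylpiperazin-1-yl would keep the activity stays open.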